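The compounds below may be only part of what the source reports. "The series", "measured", "known", "first", "only" and "open" are said of these compounds alone.

Working notes on the series. Within the data shown here, compound 2 `C=CCc1cc(C(C)=O)c(O)cc1OCCCCC` gives in an assay on isolated protein for inhibition of leukotriene B4 receptor 1 (Homo sapiens), tested at 10 uM (a lower number here means less inhibition, a higher number more inhibition at the concentration tested (going by the name of the read-out)), compound 2 60%, the lowest of the two numbers so far. Among the measured compounds shown here, compound 1 `C=CCc1cc(C(C)=O)c(O)cc1OCCCCCCCCC#N`, which carries 3-cyanopropyl on the same chain carbon, gives in this assay compound 1 86%; the step of a number 26 percentage points lower from compound 1 to compound 2 (beyond the scatter) is the only measured comparison available, modest and beyond the scatter. Compound 3 `C=CCc1cc(C(C)=O)c(O)cc1OCCCCCC(C)=O` is not yet measured. The change acetyl in place of hydrogen on a saturated chain carbon, five bonds along the chain from an oxygen on an aromatic ring puts a group back on a saturated chain carbon, five bonds along the chain from an oxygen on an aromatic ring, the same place where the measured step removed one, so that step is the one that bears on it. A step in the same upward direction, of similar or somewhat smaller size, is therefore expected in this assay, a number 16 percentage points higher from compound 2 to compound 3 (beyond the scatter). Compound 3 is estimated at 76%, within a likely range from 58% to 92%.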

Compound 3, a percentage reported as inhibition, at one concentration (the size of the read-out at that concentration, not a potency): 98%
The estimate for compound 3 lay 22 percentage points below the measured number; measured number outside the range, above it.
By their numbers in this assay, from the lowest: compound 2; then compound 1; then compound 3.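

Among these compounds, at this saturated chain carbon, five bonds along the chain from an oxygen on an aromatic ring, placing acetyl in this assay gives a number 38 percentage points higher from compound 2 to compound 3 (beyond the scatter) and so exceeds the size of the one earlier step at this place. Changing 3-cyanopropyl to acetyl gives a number 12 percentage points higher from compound 1 to compound 3 (beyond the scatter) and places compound 3 highest of the three, so among these compounds the longer of the two added groups does not give the higher number. Nothing available explains this order.

Whether the carbonyl or the terminal methyl of acetyl accounts for the step remains open. A hydroxyl, an amide or a carboxylic acid at the same chain carbon would bear on that, and a longer chain ending in a ketone would test whether the step holds as the chain grows.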